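Removing a Phenyl from Two Related Cores

The source may hold more compounds than are shown below. What is called first, only, known or untested is meant among the compounds shown, and "the series" means these compounds.

Compound 1 `CC(C)(C)C1=CC(=O)C=C(NCc2ccccc2)C1=O` carries a phenyl on a saturated chain carbon bound to an amine nitrogen; in a functional assay on NCI-H460 cells (Homo sapiens) for cytotoxicity, read by MTT assay, with a stated time of 72 h (on this read-out lower numbers stand for stronger inhibition and higher numbers for weaker inhibition), compound 1 gives 10000 nM. Compound 2 `CNC1=CC(=O)C=C(C(C)(C)C)C1=O` differs from it by hydrogen in place of phenyl on a saturated chain carbon bound to an amine nitrogen, and in this assay compound 2 gives 23000 nM, so that a 2.3-fold higher number from compound 1 to compound 2 (0.36 log units; beyond the scatter). Compound 3 `CC(C)(C)C1=CC(=O)C(NCc2ccccc2)=CC1=O` has the same atoms as compound 1 joined differently; how the two cores differ is not broken down here. In this assay compound 3 gives 15000 nM, a number within the scatter of compound 1. Compound 4 `CNC1=CC(=O)C(C(C)(C)C)=CC1=O` has not been measured; it differs from compound 3 by hydrogen in place of phenyl on a saturated chain carbon bound to an amine nitrogen, the same change as that between compound 1 and compound 2. Because that change gave a 2.3-fold higher number from compound 1 to compound 2 (0.36 log units; beyond the scatter), a similar weakening is expected here, namely a 2.2-fold higher number from compound 3 to compound 4 (0.34 log units; beyond the scatter). Compound 4 is therefore estimated at 33000 nM.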

Compound 4, half-maximal inhibitory concentration: 58000 nM
For compound 4 the middle estimate is 1.8-fold (0.24 log units) below the measured one; the measured number falls inside the stated range.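

Replacing phenyl with hydrogen on a saturated chain carbon bound to an amine nitrogen again weakens the result in this assay, with a 3.9-fold higher number from compound 3 to compound 4 (0.59 log units; beyond the scatter). The change therefore points the same way on both cores, and the two steps cannot be told apart in size: the same change on two cores in this assay, a 2.3-fold higher number (0.36 log units; beyond the scatter) from compound 1 to compound 2 and a 3.9-fold higher number (0.59 log units; beyond the scatter) from compound 3 to compound 4, 1.7-fold (0.23 log units) apart, within the scatter of two such steps. This shows that the loss carries over between these two cores in this one assay, but it does not show that it would hold on any other core or in any other assay.

Only phenyl and hydrogen appear at this place, so the compounds shown leave open how a cyclohexyl or pyridine ring there would compare. They also leave open whether a chlorophenyl group would shift the number on either core.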